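This account rests on a few compounds, and the source may have more. Where it says the series, first, only, none or still open, it means among the compounds named here.

Measured compounds in an assay on isolated protein for inhibition of phosphatidylinositol 4,5-bisphosphate 3-kinase catalytic subunit beta isoform (Homo sapiens); on this read-out higher numbers stand for weaker inhibition and lower numbers for stronger inhibition:
- compound 1 `COc1ccc(-c2ccnc(Nc3ccc([N+](=O)[O-])cc3)n2)cc1` gives 537 nM
- compound 2 `COc1ccc(-c2ccnc(Nc3ccc(Cl)cc3Cl)n2)cc1` gives 839 nM
- compound 3 `Clc1ccc(Nc2nccc(-c3ccc(Br)cc3)n2)c(Cl)c1` gives 673 nM

Compound 1 holds the lowest of the three numbers in this assay, but its nearest neighbour, compound 3, sits within the scatter of it, and compound 2 does as well, so no order among the three can be claimed.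

The unmeasured compound 4 `O=[N+]([O-])c1ccc(Nc2nccc(-c3ccc(Cl)c(Cl)c3)n2)cc1` differs from compound 1 in one place: 3,4-dichlorophenyl in place of 4-methoxyphenyl on an aromatic carbon. Within the data shown here, the only measured step that bears on this change is the one from compound 2 to compound 3, where the methoxy on the same aryl was exchanged for bromo and the result was a 1.2-fold lower number from compound 2 to compound 3 (0.10 log units; within the scatter). That step carries the shared core with the dichloroanilino substituent rather than the nitroanilino one of compound 1, so it is an indirect guide, but it is the only one available. It suggests that replacing the methoxy-bearing aryl by a halogen-bearing aryl does little in this assay.

Accordingly, compound 4 is expected to stay close to compound 1, with a step of a 1.1-fold higher number from compound 1 to compound 4 (0.05 log units; within the scatter), none beyond the scatter. The estimate for compound 4 in this assay is 600 nM, with a range from 250 nM to 1500 nM.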

Compound 4, half-maximal inhibitory concentration: 573 nM
Compound 4: middle estimate off by 1.0-fold (0.02 log units), on the high side; low and high end bracket the measured number.
By their numbers in this assay, from the lowest: compounds 1, 4, 3 and 2 (each within the scatter of the next).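

In this assay, 3,4-dichlorophenyl in place of 4-methoxyphenyl on the aromatic carbon next to the ring nitrogen gives a 1.1-fold higher number from compound 1 to compound 4 (0.03 log units; within the scatter), so the two aryl groups are not separated at this position, although the leaving group carries a hydrogen-bond acceptor and the entering group carries none. The earlier exchange of methoxy for bromo gave a 1.2-fold lower number from compound 2 to compound 3 (0.10 log units; within the scatter) with the dichloroanilino substituent in place, and the new step extends the same flat reading to the nitroanilino series and to an aryl with two chlorines, with no listed step at this position going against it. No data on any property of these groups are available to explain this result.

On these data alone, all the aryl groups compared at this position are six-membered aromatic carbon rings bearing methoxy or halogen, so it remains open whether any change here can produce a step beyond the scatter. An aryl bearing a carboxylic acid or a basic amine, or a saturated ring such as morpholine in place of the aryl, would test how far this tolerance extends.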